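A few compounds are considered here, and "the series" means these few. Any claim that something is new, unique, unknown or untested is made for them only; others in the source may bear on it.

In a functional assay on LoVo cells (Homo sapiens) for inhibition, read by MTT assay, with a stated time of 72 h (a lower number here means a stronger inhibitor, a higher number a weaker inhibitor), compound 1 `Cc1noc(C)c1-c1cnc(N)c(Oc2ccc(C(=O)Nc3ccccc3)cc2)n1` gives 5740 nM, and compound 2 `Cn1cc(-c2cnc(N)c(Oc3ccc(C(=O)Nc4ccccc4)cc3)n2)cn1` gives 9210 nM. Among the measured compounds shown here, the only measured step, a 1.6-fold higher number from compound 1 to compound 2 (0.21 log units; within the scatter), is within the scatter, so the two numbers sit together and compound 2 has no separate standing. Compound 3 `Cn1cc(-c2cnc(N)c(Oc3ccc(C(=O)Nc4ccc(Cl)cc4)cc3)n2)cn1` differs from compound 2 by chloro in place of hydrogen on an aromatic carbon. For the measured compounds named here, no measured step touches the ring that takes the chloro; the single known step concerns a different part of the molecule and gives no direction. The step expected for compound 3 is a 1.2-fold lower number from compound 2 to compound 3 (0.09 log units; within the scatter), nothing beyond the scatter. Compound 3 is estimated at 7500 nM, ranging from 3000 nM to 20000 nM.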

Compound 3, half-maximal inhibitory concentration: 3080 nM
For compound 3 the middle estimate is 2.4-fold (0.39 log units) above the measured one; low and high end bracket the measured number.
By their numbers in this assay, from the lowest: compounds 3, 1 and 2 (each within the scatter of the next, the first and the last beyond it).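

In this assay, going from phenylcarbamoyl to (4-chlorophenyl)carbamoyl gives a 3.0-fold lower number from compound 2 to compound 3 (0.48 log units; beyond the scatter). This shows that a single chlorine on this outer phenyl ring can move the number beyond the scatter, which the earlier exchange of 3,5-dimethyl-1,2-oxazol-4-yl for 1-methyl-1H-pyrazol-4-yl did not do. No measurement at hand accounts for this step.

On these data alone, whether the step belongs to chloro itself remains open, and a fluoro, methyl, methoxy or amine at the same place would test that. As far as these compounds go, it is also open whether chloro gives a similar step on compound 1.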